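This account rests on a few compounds, and the source may have more. Where it says the series, first, only, none or still open, it means among the compounds named here.

Compound 1 `O=C(NCCCCc1ccccc1)n1c(=O)oc2ccccc21` is the starting point in a physicochemical assay for metabolic stability, read by HPLC, in phosphate buffer, at pH 7.4, tested at 10 uM; a lower number here means that the compound disappears faster, a higher number that the compound lasts longer. In this test compound 1 gives 0.75 h, the only exact half-life known so far. Compound 2 `O=C(NCCCCc1ccccc1)n1c(=O)oc2cc(-c3ccc(F)cc3)ccc21` gives > 5 h, and that value is a limit of the assay, not a number.

Compound 3 `O=C(NCCCCc1ccccc1)n1c(=O)oc2ccc(-c3ccccc3)cc21` has not yet been measured. It differs from compound 1 as follows: phenyl in place of hydrogen on an aromatic carbon. In words, a phenyl takes the place of a hydrogen on an aromatic carbon.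

Going by the values given here, one measured step bears on this change: an at least 6.6-fold higher number from compound 1 to compound 2 (0.82 log units; beyond the scatter), which is beyond the scatter. Its size is only a bound, set by the limit of > 5 h in this assay, at which 1 of the 2 values shown sits. That step adds a 4-fluorophenyl rather than a phenyl, and on a different aromatic carbon, so it is an imperfect guide. A rise in this assay is therefore expected, but a more cautious one, because compound 2 showed an at least 6.6-fold higher number from compound 1 to compound 2 (0.82 log units; beyond the scatter) only with its own group and place. The estimated change is a 3.3-fold higher number from compound 1 to compound 3 (0.52 log units; beyond the scatter). For compound 3 the expected half-life is 2.5 h, with an estimated range from 0.9 h to 7 h.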

Compound 3, half-life: 4.93 h
For compound 3 the middle estimate is 2.0-fold (0.29 log units) below the measured one; the measured number falls inside the stated range.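

In this assay, going by these compounds alone, a phenyl in place of hydrogen brings a 6.6-fold higher number from compound 1 to compound 3 (0.82 log units; beyond the scatter), and this is the first size for such a change with a number at both ends. It also shows that a rise beyond the scatter needs no fluorine on the added ring and is not confined to the aromatic carbon used in compound 2, since the phenyl of compound 3 sits on a different aromatic carbon, meta to a fused ring and para to a fused ring. Compound 2 gives > 5 h, a limit of the assay and not a number, so whether its group and place do more or less than those of compound 3 cannot be read from these values: the limit of > 5 h in this assay, at which 1 of the 3 values shown sits.

The compounds shown leave open whether a phenyl on the aromatic carbon used in compound 2 would behave as it does in compound 3, and whether the fluorine matters at all. They also leave open whether the rise needs an aromatic ring, or whether a methyl, a methoxy, an amine or a carboxylic acid on the same carbon would give a similar number.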